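Cytotoxicity notes: chain extension from compound 3 to compound 4

The source may hold more compounds than are shown below. What is called first, only, known or untested is meant among the compounds shown, and "the series" means these compounds.

Measured compounds:
compound 1 `CCCNc1nc(C)nc2c1cnn2-c1ccccc1` with > 100000 nM
compound 2 `CCCCNc1nc(C)nc2c1cnn2-c1ccccc1` with > 100000 nM
compound 3 `CCNc1nc(C)nc2c1cnn2-c1ccccc1` with > 100000 nM

In a functional assay on G-361 cells (Homo sapiens) for cytotoxicity, read by sulforhodamine B assay (a higher number here means that more compound is tolerated, a lower number that less compound is tolerated), compound 1 gives > 100000 nM, which is a limit of the assay and not a number. Compound 2 likewise gives > 100000 nM, a limit. Compound 3 gives > 100000 nM, again a limit. Accordingly the three steps among them, a step that the two limits leave unreadable from compound 1 to compound 2, a step that the two limits leave unreadable from compound 1 to compound 3 and a step that the two limits leave unreadable from compound 2 to compound 3, cannot be read in size; all three values sit at the limit of > 100000 nM in this assay, at which 3 of the 3 values shown sit.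

Compound 3 therefore stands at the limit of this assay, together with compounds 1 and 2, with no ordering possible among them.

Compound 4 `CCNCc1nc(NCC)c2cnn(-c3ccccc3)c2n1` differs from compound 3 by ethylamino in place of hydrogen on a saturated chain carbon bound to an aromatic carbon. For the measured compounds named here, no measured step touches this position; the steps among compounds 1, 2 and 3 concern the chain on the amino nitrogen and are all unreadable. There is thus no measured basis for expecting any change beyond the scatter, and the expected step that the limit leaves unreadable from compound 3 to compound 4 is set at none. For compound 4 the value in this assay is expected at 120000 nM, within a range of 40000 nM to 400000 nM, most likely reported again as a limit.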

Compound 4, concentration lethal to 50% of the cells: > 100000 nM
Compound 4 ended at the assay's limit; the forecaster's own chance of this, stated with the estimate: 80%; the middle value is on the limit's open side.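

No new step can be read: in this assay compound 4 gives > 100000 nM, a limit of the assay and not a number. Its comparison with compound 3 stays unreadable, and the series stands thus: the limit of > 100000 nM in this assay, at which 4 of the 4 values shown sit.

The compounds shown leave open whether compounds 1, 2, 3 and 4 differ at all in this assay, and what change to the shared core would give a readable value.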